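This account rests on a few compounds, and the source may have more. Where it says the series, first, only, none or still open, it means among the compounds named here.

Three compounds share one core, differing only in the aryl group attached to a nitrogen on an aromatic ring. Compound 1 `CNC(=O)c1ccccc1Oc1nc(Nc2ccc(Br)cc2)ncc1Br` carries a 4-bromophenyl group there. In a functional assay on U-937 cells (Homo sapiens) for antiproliferative activity, read by MTT assay, with a stated time of 24 h (a higher number here means a weaker inhibitor, a lower number a stronger inhibitor), compound 1 reaches only the limit of > 50000 nM. Compound 2 `CNC(=O)c1ccccc1Oc1nc(Nc2ccc(Cl)cc2F)ncc1Br` carries a 4-chloro-2-fluorophenyl group instead, and in this assay compound 2 also stops at the limit of > 50000 nM. Within the data shown here, compound 3 `CNC(=O)c1ccccc1Oc1nc(Nc2cccc(OC)c2)ncc1Br` carries a 3-methoxyphenyl group, and in this assay compound 3 gives 24300 nM, the only true number among the three, the others sitting at the limit of > 50000 nM in this assay, at which 2 of the 3 values shown sit. The steps to it read an at least 2.0-fold lower number from compound 1 to compound 3 (0.31 log units; beyond the scatter) and an at least 2.0-fold lower number from compound 2 to compound 3 (0.31 log units; beyond the scatter).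

Compound 4 `CNC(=O)c1ccccc1Oc1nc(Nc2cccc(C(C)C)c2)ncc1Br` changes the 3-methoxyphenyl group: isopropyl in place of methoxy on an aromatic carbon. Among the measured compounds shown here, no measured step swaps one group for another at this same position while keeping the rest, so the two steps into compound 3 only show that this arrangement can reach a readable number. On that basis the expected change in this assay is a 1.1-fold lower number from compound 3 to compound 4 (0.04 log units; within the scatter), within the scatter. Compound 4 is therefore estimated at 22000 nM, with a likely range from 7000 nM to 60000 nM.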

Compound 4, half-maximal inhibitory concentration: 14100 nM
The estimate for compound 4 lay 1.6-fold (0.19 log units) above the measured number; measured number inside the range.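

In this assay, among these compounds, the change from methoxy to isopropyl on the aromatic carbon is the only measured step that alters just this one group while keeping the rest of the molecule, and it gives a 1.7-fold lower number from compound 3 to compound 4 (0.24 log units; within the scatter), so the two groups cannot be told apart here. A readable number is therefore not tied to methoxy, since the 3-isopropylphenyl group also reaches one, as the steps to it show: an at least 3.5-fold lower number from compound 2 to compound 4 (0.54 log units; beyond the scatter), and an at least 3.5-fold lower number from compound 1 to compound 4 (0.54 log units; beyond the scatter). Both of these steps give only a smallest possible size rather than a true one, because compound 1 and compound 2 each stop at a limit and not at a real number: the limit of > 50000 nM in this assay, at which 2 of the 4 values shown sit.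

Going by these compounds, only methoxy and isopropyl appear at this place, so it remains open how an amine, a carboxylic acid or a longer chain there would change the number. It also remains open whether the identity of the group or its place on the ring matters more, as no compound shown carries methoxy or isopropyl anywhere else on that ring.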